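Shifting the Fluorine: From Compound 1 to Compound 3

A few compounds are considered here, and "the series" means these few. Any claim that something is new, unique, unknown or untested is made for them only; others in the source may bear on it.

Measured compounds:
Compound 1 `COc1ccc(C2=NN(C(=O)C3COc4ccccc4O3)C(c3cccc(F)c3)C2)cc1`: 6720 nM
Compound 2 `O=C(C1COc2ccccc2O1)N1N=C(c2ccc(Br)cc2)CC1c1cccc(F)c1`: 7810 nM

Both were tested in a functional assay on WM 266-4 cells (Homo sapiens) for inhibition, read by MTT assay, with a stated time of 24 h; on this read-out lower numbers stand for stronger inhibition of growth and higher numbers for weaker inhibition of growth. On the numbers shown, compound 1 has the lower of the two, but the only measured step, a 1.2-fold higher number from compound 1 to compound 2 (0.07 log units; within the scatter), lies within the scatter, so the two compounds cannot really be told apart on this read-out. That step swaps a group on one aromatic ring and leaves the rest of the shared core untouched.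

Compound 3 `COc1ccc(C2=NN(C(=O)C3COc4ccccc4O3)C(c3ccccc3F)C2)cc1` has not yet been measured. It differs from compound 1 only at the fluorophenyl group: 2-fluorophenyl in place of 3-fluorophenyl on a saturated ring carbon. For the measured compounds named here, no measured step touches this part of the core, so the single step between compound 1 and compound 2 gives no direct guidance; it only shows that a small swap on an aromatic ring moved the number by a 1.2-fold higher number from compound 1 to compound 2 (0.07 log units; within the scatter), which is within the scatter.

With nothing pointing either way, compound 3 is expected to stay close to compound 1, with a 1.0-fold higher number from compound 1 to compound 3 (0.02 log units; within the scatter) not beyond the scatter. The estimate for compound 3 is 7000 nM, in the range 3000 nM to 16000 nM.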

Compound 3, concentration for 50% growth inhibition: 5720 nM
Beside the measured number, compound 3's estimate is 1.2-fold (0.09 log units) above it, and the stated range covers the measured number.
By their numbers in this assay, from the lowest: compounds 3, 1 and 2 (each within the scatter of the next).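

For the compounds shown here, this is the first measured change at the group on the saturated ring carbon next to the ring nitrogen. In this assay, 2-fluorophenyl in place of 3-fluorophenyl gives a 1.2-fold lower number from compound 1 to compound 3 (0.07 log units; within the scatter), so for these two compounds, moving the fluorine around the phenyl ring produces no difference that can be read above the usual variation between repeat measurements. The earlier pair could not show this, since compound 1 and compound 2 differ only in the group on the other aromatic ring, and together the two steps now show that neither of these single swaps, one at each aryl group, separates the compounds on this read-out. No measurement here offers an explanation for why the two fluorophenyl compounds read alike.

The compounds shown leave open whether this saturated ring carbon tolerates anything beyond a fluorophenyl group, since every compound here carries one. A plain phenyl, 4-fluorophenyl, or a phenyl bearing an amine or a carboxylic acid at that carbon would test whether any change there can move the number beyond the scatter.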